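Taking one methyl off compound 2

The compounds below may be only part of what the source reports. "The series", "measured", "known", "first", "only" and "open" are said of these compounds alone.

In an in vitro ADME assay on microsomes from liver (Mus musculus) for pharmacokinetics, read by LC-MS (on this read-out higher numbers stand for fast clearance and lower numbers for slow clearance), compound 1 `Cc1nc2c(F)cccc2n1-c1ccc(C(=O)NC2CC2)s1` gives 37 mL/min/kg. Compound 2 `Cc1cc(F)c2nc(C)n(-c3ccc(C(=O)NC4CC4)s3)c2c1` stands at > 72 mL/min/kg, which is a limit of the assay and not a number. Compound 3 `Cc1cc(F)c2ncn(-c3ccc(C(=O)NC4CC4)s3)c2c1`, not yet measured, differs from compound 2 by hydrogen in place of methyl on an aromatic carbon, between two ring nitrogen atoms. Among the measured compounds shown here, the one measured step of this kind, running the other way with methyl in place of hydrogen on an aromatic carbon, gave an at least 1.9-fold higher number from compound 1 to compound 2 (0.28 log units; that floor lies within the scatter), so no step beyond the scatter is expected in this assay. The expected step is an at least 1.2-fold lower number from compound 2 to compound 3 (0.07 log units; that floor lies within the scatter). Compound 3 is estimated at 60 mL/min/kg, within a range of 32 mL/min/kg to 110 mL/min/kg.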

Compound 3, clearance: > 72 mL/min/kg
Compound 3 gave a limit, no number; the forecaster's own chance of this, stated with the estimate: 40%; middle value at least 1.2-fold (0.07 log units) from the limit.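

In this assay, among the compounds shown here, compound 2 and compound 3 both give a limit rather than a number, so no step between them can be read: the limit of > 72 mL/min/kg in this assay, at which 2 of the 3 values shown sit. On these data alone, whether hydrogen in place of methyl, between two ring nitrogen atoms, changes clearance at all stays open.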